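The compounds below may be only part of what the source reports. "The series", "measured", "known", "first", "only" and "open" are said of these compounds alone.

Compound 2, `CCOc1ccccc1-c1ccc(-c2nc3cnccc3c(C[C@H](C)C(=O)O)c2C#N)cc1`, in a physicochemical assay for lipophilicity, read by HPLC, at pH 7.5 (on this read-out lower numbers stand for lower lipophilicity and higher numbers for higher lipophilicity), gives 2.2. Compound 1, `CCOc1ccccc1-c1ccc(-c2nc(NC(C)C(=O)O)c3ccncc3n2)cc1`, gives 2.1 in this assay, and these two values lie within the usual scatter of each other. Compound 3, `CCOc1ccccc1-c1ccc(-c2nc3cnccc3c(NC(C)C(=O)O)c2C#N)cc1`, has not yet been measured in this assay. It differs from compound 2 in one place: (1-carboxyethyl)amino in place of 2-carboxypropyl on an aromatic carbon. Going by the values given here, no measured pair shows this exact change, so its effect has to be estimated. The step of a number 0.30 log units lower from compound 2 to compound 3 (within the scatter) is expected to be small and downward, about the size of the scatter. The estimate for compound 3 in this assay is 1.9, ranging from 1.5 to 2.3.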

Compound 3, distribution coefficient: 2.1
Estimate against measurement, compound 3: 0.20 log units below; the measured number falls inside the stated range.
By their numbers in this assay, from the lowest: compounds 1, 3 and 2 (each within the scatter of the next).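

At this aromatic carbon, opposite the ring nitrogen, (1-carboxyethyl)amino in place of 2-carboxypropyl gives a number 0.10 log units lower from compound 2 to compound 3 (within the scatter) in this assay. In this one pair, the exchange shows no shift beyond the scatter, even though the counts of hydrogen-bond donors and acceptors differ. Nothing available explains this result. As far as these compounds go, what remains open is how a simple amine, an amide or a longer chain ending in a carboxylic acid would read at this carbon.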